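Benzyl for 4-methylphenoxy: a step from compound 2 onward

The compounds below may be only part of what the source reports. "The series", "measured", "known", "first", "only" and "open" are said of these compounds alone.

Of the compounds shown here, two have been measured in an assay for inhibition of Thromboxane-A synthase (Homo sapiens), using microsomes; on this read-out lower numbers stand for stronger inhibition and higher numbers for weaker inhibition. Compound 1 `O=C(O)CC/C=C\CC1COC(c2ccc(Cl)cc2Cl)OC1c1cccnc1` gives 42 nM, and compound 2 `Cc1ccc(OC(C)(C)C2OCC(C/C=C\CCC(=O)O)C(c3cccnc3)O2)cc1` gives 360 nM, the higher of the two numbers, with the gap to compound 1 lying beyond the scatter. Compound 3 `CC(C)(Cc1ccccc1)C1OCC(C/C=C\CCC(=O)O)C(c2cccnc2)O1` is not yet measured; it differs from compound 2 by benzyl in place of 4-methylphenoxy on a saturated chain carbon bound to two saturated chain carbons and a saturated ring carbon. No step of this kind has been measured among these compounds, so the expected step from compound 2 to compound 3 is a modest lowering, a 1.4-fold lower number from compound 2 to compound 3 (0.16 log units; within the scatter), with little confidence in its direction. For compound 3 the estimate in this assay is 250 nM, within 80 nM to 800 nM.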

Compound 3, half-maximal inhibitory concentration: 12 nM
For compound 3 the middle estimate is 21-fold (1.32 log units) above the measured one; measured number outside the range, below it.
By their numbers in this assay, from the lowest: compound 3; then compound 1; then compound 2.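

In this assay the exchange of 4-methylphenoxy for benzyl on this saturated chain carbon gives a 30-fold lower number from compound 2 to compound 3 (1.48 log units; beyond the scatter) and so shows that the position responds strongly to a change that keeps the six-membered aromatic ring and drops the oxygen. The 1-benzyl-1-methylethyl group on the saturated ring carbon also outdoes 2,4-dichlorophenyl, with a 3.5-fold lower number from compound 1 to compound 3 (0.54 log units; beyond the scatter) as the step. No measured evidence bears on the reason for either step. On these data alone, whether a cyclohexylmethyl group would hold the low number in place of benzyl remains open, as does the effect of a chlorine on the benzyl ring.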